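A few compounds are considered here, and "the series" means these few. Any claim that something is new, unique, unknown or untested is made for them only; others in the source may bear on it.

Measured compounds:
Compound 1, `CCN(CC)c1ccc2cc(C(=O)c3ccc(N4CCN(C(=O)CN5CCN(S(=O)(=O)C6CC6)CC5)CC4)cc3)oc2c1`. In a functional assay on HCT-116 cells (Homo sapiens) for cytotoxicity, read by MTT assay, with a stated time of 48 h (on this read-out lower numbers stand for stronger inhibition and higher numbers for weaker inhibition), compound 1 gives > 40000 nM, which is a limit of the assay and not a number.
Compound 2, `CCN(CC)c1ccc2cc(C(=O)c3ccc(N4CCN(C(=O)CN5CCN(S(=O)(=O)c6ccc(F)cc6)CC5)CC4)cc3)oc2c1`. In this assay compound 2 gives > 40000 nM, again a limit of the assay.

Compound 1 therefore stands only at a limit in this assay; no finite inhibitory concentration is known for it, and the same holds for compound 2. Within the data shown here, the single step between measured compounds, a step that the two limits leave unreadable from compound 1 to compound 2, cannot be read in size or direction, as the limit of > 40000 nM in this assay, at which 2 of the 2 values shown sit, makes clear.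

Compound 3, `CCOC(=O)CN1CCN(CC(=O)N2CCN(c3ccc(C(=O)c4cc5ccc(N(CC)CC)cc5o4)cc3)CC2)CC1`, is not yet measured in this assay. It differs from compound 1 in one place: (ethoxycarbonyl)methyl in place of cyclopropylsulfonyl on an amine nitrogen in a ring. Among the measured compounds shown here, no measured step bears directly on this change; the only comparison available, from compound 1 to compound 2, is unreadable, so it gives no size and no direction. With both measured values sitting at the limit, the expectation for compound 3 rests on that limit alone.

For compound 3 an inhibitory concentration of 40000 nM is expected in this assay, with a range from 15000 nM to 100000 nM. This estimate means a number no higher from compound 1 to compound 3 (the limit leaves the size open), that is, no step beyond the scatter is expected, and most likely the assay again reports only a limit.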

Compound 3, half-maximal inhibitory concentration: > 40000 nM
Compound 3 was reported as a limit; the forecaster's own chance of this, stated with the estimate: 70%; the middle value lies on the limit itself.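

In this assay compound 3 gives > 40000 nM, a limit of the assay and not a number. Among these compounds, no step from compound 1 or compound 2 to compound 3 can be read, in size or direction: the limit of > 40000 nM in this assay, at which 3 of the 3 values shown sit. The compounds shown leave open whether any of these groups on the amine nitrogen in a ring changes the inhibitory concentration.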